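The source may hold more compounds than are shown below. What is called first, only, known or untested is meant among the compounds shown, and "the series" means these compounds.

Of the compounds shown here, three built on one shared core have been tested in an ADME assay on Vero cells (Chlorocebus sabaeus) for cytotoxicity, read by WST assay; a lower number here means that less compound is tolerated, a higher number that more compound is tolerated. Compound 1 `O=c1[nH]c(NCC2CCCCC2)nc2cc(Cl)ccc12` gives > 25000 nM, which is a limit rather than a measured number. Compound 2 `O=c1[nH]c(Nc2cc(F)cc(F)c2)nc2cc(C(F)(F)F)ccc12` gives >= 7600 nM, again a limit. Within the data shown here, compound 3 `O=c1[nH]c(Nc2cc(Cl)cc(Cl)c2)nc2cc(C(F)(F)F)ccc12` gives 7100 nM, the only number among the three values shown. The values of compound 1 and compound 2 are limits. Among the measured compounds shown here, the single step between measured compounds that differ in one place is an at least 1.0-fold lower number from compound 2 to compound 3 (0.02 log units; that floor lies within the scatter), a change on a nitrogen on an aromatic ring that stays within the scatter.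

Compound 4 `O=c1[nH]c(Nc2cc(Cl)cc(Cl)c2)nc2cc(O)ccc12` has not yet been measured. It differs from compound 3 by hydroxy in place of trifluoromethyl on an aromatic carbon. For the measured compounds named here, no measured step touches this part of the molecule. Going by the values given here, the only available step, an at least 1.0-fold lower number from compound 2 to compound 3 (0.02 log units; that floor lies within the scatter), alters the other ring and lies within the scatter, and the two limits the limit of > 25000 nM in this assay, at which 1 of the 3 values shown sits, and the limit of >= 7600 nM in this assay, at which 1 of the 3 values shown sits, give no direction either. There is therefore no basis for expecting a step beyond the scatter in this assay. Compound 4 is expected to give about 8000 nM, with a range from 3000 nM to 25000 nM, which corresponds to an expected step of a 1.1-fold higher number from compound 3 to compound 4 (0.05 log units; within the scatter).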

Compound 4, half-maximal cytotoxic concentration: > 25000 nM
Compound 4 ended at the assay's limit (the forecaster's own chance of this, stated with the estimate: 40%); at least 3.1-fold (0.49 log units) between middle value and limit.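

Among these compounds, replacing trifluoromethyl with hydroxy on this aromatic carbon of the shared core gives an at least 3.5-fold higher number from compound 3 to compound 4 (0.54 log units; beyond the scatter), the first step in this assay that clears the scatter, and it means that more compound is tolerated. Among the compounds shown here, the earlier step, an at least 1.0-fold lower number from compound 2 to compound 3 (0.02 log units; that floor lies within the scatter), changed the other ring and stayed within the scatter, so this position is the first place where a single change is seen to shift the tolerated concentration. Compound 4 gives > 25000 nM, which is a limit, so the step shown is only a floor and its full size stays unknown, and this ceiling is one that the series reaches more than once: the limit of > 25000 nM in this assay, at which 2 of the 4 values shown sit.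

Going by these compounds, what drives the shift remains open, since the change removes trifluoromethyl and introduces hydroxy in one move, and a plain hydrogen at this position would help to separate those two events. A methoxy group, an amine or a carboxylic acid on the same carbon would show whether the higher number is particular to hydroxy or is shared by other replacements for trifluoromethyl.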